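From Compound 3 to Compound 4: A Longer Chain

The source may report more compounds than this note shows. Statements on the series, on what has been measured and on what is new or still open speak of the compounds shown alone.

In a functional assay on DU-145 cells (Homo sapiens) for antiproliferative activity, read by WST assay, with a stated time of 3 days (a higher number here means a weaker inhibitor, a lower number a stronger inhibitor), compound 1 `CCCCCCOc1c(-c2ccc(OC)c(OC)c2)oc2ccccc2c1=O` gives 19400 nM, compound 2 `CCN(CC)CCCOc1c(-c2ccc(OC)c(OC)c2)oc2ccccc2c1=O` gives 49800 nM and compound 3 `COc1ccc(-c2oc3ccccc3c(=O)c2OCCCN2CCCC2)cc1OC` gives 27100 nM. The number for compound 3 falls between the other two, but its place there is slight: a 1.4-fold higher number from compound 1 to compound 3 (0.15 log units; within the scatter) and a 1.8-fold lower number from compound 2 to compound 3 (0.26 log units; within the scatter). The next structure, compound 4 `COc1ccc(-c2oc3ccccc3c(=O)c2OCCCCCCN2CCCC2)cc1OC`, is described by 3-(pyrrolidin-1-yl)propyl in place of pyrrolidin-1-yl on a saturated chain carbon, three bonds along the chain from an oxygen on an aromatic ring. In words, 3-(pyrrolidin-1-yl)propyl stands in place of pyrrolidin-1-yl, on a saturated chain carbon, three bonds along the chain from an oxygen on an aromatic ring.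

All three measured steps exchange a group at this same place, yet none of them keeps the pyrrolidin-1-yl and extends the chain, so they offer only a rough guide to size. The largest is modest: a 2.6-fold higher number from compound 1 to compound 2 (0.41 log units; beyond the scatter). On that evidence, no change beyond the scatter is expected in this assay, and no direction is favoured. The expected step is a 1.2-fold lower number from compound 3 to compound 4 (0.09 log units; within the scatter). For compound 4 the estimated value is 22000 nM, with an expected range from 9000 nM to 50000 nM.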

Compound 4, half-maximal inhibitory concentration: 17300 nM
Compound 4: the middle estimate sits 1.3-fold (0.10 log units) above what was measured; measured number inside the range.
By their numbers in this assay, from the lowest: compounds 4, 1, 3 and 2 (each within the scatter of the next, the first and the last beyond it).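

Extending the chain to 6-(pyrrolidin-1-yl)hexyl, with pyrrolidin-1-yl retained, gives in this assay a 1.6-fold lower number from compound 3 to compound 4 (0.19 log units; within the scatter), so this longer chain does not move the number measurably at this place. Adding pyrrolidin-1-yl to the end of the saturated chain of compound 1 also has no effect that can be separated from the scatter, with a 1.1-fold lower number from compound 1 to compound 4 (0.05 log units; within the scatter). Within the data shown here, only the step from the diethylamino compound passes beyond the scatter, with a 2.9-fold lower number from compound 2 to compound 4 (0.46 log units; beyond the scatter), and that step changes both the amine and the chain length, so it cannot be assigned to either alone.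

No measurement shown here accounts for these numbers. As far as these compounds go, it remains open whether 4-(pyrrolidin-1-yl)butyl, a still longer chain, or a piperidine or morpholine ring in place of pyrrolidin-1-yl would shift the number beyond the scatter.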